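Aryl swap on the hydrazone carbon of the shared core

The source may report more compounds than this note shows. Statements on the series, on what has been measured and on what is new or still open speak of the compounds shown alone.

Among the compounds with values here, compound 2 `O=C(CSc1nnc(-c2ccncc2)o1)N/N=C/c1ccccc1F` gives 142000 nM in an ADME assay on NIH3T3 cells (Mus musculus) for cytotoxicity, read by MTT assay, with a stated time of 24 h (on this read-out higher numbers stand for weaker inhibition and lower numbers for stronger inhibition), one of only two numbers so far; compound 1 `O=C(CSc1nnc(-c2ccncc2)o1)N/N=C/c1ccc([N+](=O)[O-])cc1` gives 195000 nM in this assay, and the step of a 1.4-fold lower number from compound 1 to compound 2 (0.14 log units; within the scatter) sits within the scatter. Compound 3 `O=C(CSc1nnc(-c2ccncc2)o1)N/N=C/c1cc(Cl)ccc1O` differs from compound 2 by 5-chloro-2-hydroxyphenyl in place of 2-fluorophenyl on a carbon with a double bond to nitrogen. Within the data shown here, the single step that bears on this, the change a 1.4-fold lower number from compound 1 to compound 2 (0.14 log units; within the scatter) on the same carbon, was within the scatter, so no shift beyond the scatter is expected for the step of a 1.1-fold higher number from compound 2 to compound 3 (0.02 log units; within the scatter). For compound 3 a value of 150000 nM is estimated, within a range of 50000 nM to 400000 nM.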

Compound 3, half-maximal inhibitory concentration: 166000 nM
Compound 3: the middle estimate sits 1.1-fold (0.04 log units) below what was measured, and the stated range covers the measured number.
By their numbers in this assay, from the lowest: compounds 2, 3 and 1 (each within the scatter of the next).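

In this assay the 5-chloro-2-hydroxyphenyl group brings a hydrogen-bond donor and acceptor onto the carbon with a double bond to nitrogen, yet the number shows a 1.2-fold higher number from compound 2 to compound 3 (0.07 log units; within the scatter) and also a 1.2-fold lower number from compound 1 to compound 3 (0.07 log units; within the scatter). Compounds 1, 2 and 3 therefore cannot be told apart on this read-out, despite carrying three different aryl groups at this place. No supporting data bear on this result.

From the compounds shown here alone, it remains open whether an amine, a carboxylic acid or a longer alkyl chain at this place would give a step beyond the scatter.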